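This account rests on a few compounds, and the source may have more. Where it says the series, first, only, none or still open, it means among the compounds named here.

Three measured compounds share a core and differ in the acidic side chain and its point of attachment. Compound 1 `O=C(O)CC1CCCC1Cc1ccc(OCc2ccc3ccccc3n2)cc1` gives 90 nM in a functional assay (lung) for inhibition, with Cavia porcellus as the target; on this read-out lower numbers stand for stronger inhibition and higher numbers for weaker inhibition. Compound 2 `CCCC(CCC(=O)O)Cc1cccc(OCc2ccc3ccccc3n2)c1` gives 70 nM in this assay. Compound 3 `CC(CCCC(=O)O)c1cccc(OCc2ccc3ccccc3n2)c1` gives 500 nM in this assay, the highest number of the three; its gap to compound 1 and its gap to compound 2 both lie beyond the scatter, so compound 3 inhibits less strongly than either of the other two on this read-out. Among the compounds with values here, no two of the measured compounds differ in a single place, so no isolated step is available.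

Compound 4 `c1cc(CCCCc2nnn[nH]2)cc(OCc2ccc3ccccc3n2)c1` has not yet been measured. Against compound 3 it shows the following change: 4-(1H-tetrazol-5-yl)butyl in place of 4-carboxy-1-methylbutyl on an aromatic carbon. The data hold no prior comparison of an acid against a tetrazole on this core, so the expectation rests only on compound 3 and the values of compounds 1 and 2. A moderate step toward stronger inhibition is expected, a 2.0-fold lower number from compound 3 to compound 4 (0.30 log units; within the scatter), but with wide uncertainty because in this assay compound 3 gives 500 nM as the only anchor. For compound 4 the estimate in this assay is 250 nM, within a range from 60 nM to 1200 nM.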

Compound 4, half-maximal inhibitory concentration: 105 nM
Compound 4: middle estimate off by 2.4-fold (0.38 log units), on the high side; the range from low to high includes it.
By their numbers in this assay, from the lowest: compounds 2, 1 and 4 (each within the scatter of the next); then compound 3.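

In this assay, a single-place comparison at this position now exists, and it reads a 4.8-fold lower number from compound 3 to compound 4 (0.68 log units; beyond the scatter) with 4-(1H-tetrazol-5-yl)butyl in place of 4-carboxy-1-methylbutyl on an aromatic carbon. A chain ending in a tetrazole therefore serves here without any carboxylic acid, and it lifts this position out of the weakest level seen so far in the series. Against the branched acid, the change to 3-(1H-tetrazol-5-yl)propyl in place of 1-(2-carboxyethyl)butyl on a saturated chain carbon bound to an aromatic carbon reads a 1.5-fold higher number from compound 2 to compound 4 (0.18 log units; within the scatter), so on this read-out these two compounds cannot be told apart, and no measurement in hand speaks to the reason for either step.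

Going by these compounds, the step from compound 3 changes the methyl branch and the end group together, so the share of each in the gain stays open. An unbranched 4-carboxybutyl chain at this place would divide the two, and a tetrazole carried on a longer chain or on a methyl-branched butyl chain would show how far the result depends on the linker.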